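The source may hold more compounds than are shown below. What is called first, only, known or untested is meant among the compounds shown, and "the series" means these compounds.

Measured in an ADME assay on BaF3 cells (Mus musculus) for antiproliferative activity, read by CCK-8 assay, with a stated time of 72 h; a higher number here means a weaker inhibitor of growth, a lower number a stronger inhibitor of growth:
- compound 1 `O=C(CCSc1ccc2c(/C=C/c3ccccn3)n[nH]c2c1)Nc1cccc(Cl)c1`: 9350 nM
- compound 2 `Cc1cccc(NC(=O)CCSc2ccc3c(/C=C/c4ccccn4)n[nH]c3c2)c1`: > 10000 nM

The reading for compound 2, > 10000 nM, is a limit of the assay and not a number. This is the limit of > 10000 nM in this assay, at which 1 of the 2 values shown sits, so compound 2 has no exact position on the scale.

Compound 3 `Cc1ccc(NC(=O)CCSc2ccc3c(/C=C/c4ccccn4)n[nH]c3c2)cc1` has the same atoms as compound 2, joined differently: 4-methylphenyl in place of 3-methylphenyl on an amide-type nitrogen. In words, 4-methylphenyl stands in place of 3-methylphenyl on an amide-type nitrogen.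

Among the compounds with values here, only one measured step bears on this change, and only indirectly, since it swaps a group rather than moving one. That step, an at least 1.0-fold higher number from compound 1 to compound 2 (0.02 log units; that floor lies within the scatter), is methyl in place of chloro on an aromatic carbon, and it gives no shift beyond the scatter. No direction can therefore be drawn from it. The expected step is a number no higher from compound 2 to compound 3 (the limit leaves the size open), with no change beyond the scatter. In this assay, compound 3 is estimated at 10000 nM. The expected range runs from 4000 nM to 20000 nM.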

Compound 3, concentration for 50% growth inhibition: > 10000 nM
Compound 3 gave a limit, no number; the forecaster's own chance of this, stated with the estimate: 65%; the middle value lies on the limit itself.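

Moving the methyl group from 3-methylphenyl to 4-methylphenyl on the amide-type nitrogen gives a step that cannot be read, as compound 2 and compound 3 both end at a limit in this assay: the limit of > 10000 nM in this assay, at which 2 of the 3 values shown sit.

Within the data shown here, neither methylphenyl group therefore gives a number on the scale, which the earlier compounds could show for only one of the two. Replacing the 3-chlorophenyl of compound 1 with 4-methylphenyl gives an at least 1.0-fold higher number from compound 1 to compound 3 (0.02 log units; that floor lies within the scatter), and this floor leaves the true size of the step unknown.

From the compounds shown here alone, whether any group on this nitrogen can give a clearly lower number remains open. The compounds shown say nothing about a phenyl ring carrying an amine or a carboxylic acid in place of the methyl.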